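A few compounds are considered here, and "the series" means these few. Any claim that something is new, unique, unknown or untested is made for them only; others in the source may bear on it.

Measured so far in a functional assay on cells (Lymphocyte, Homo sapiens); a lower number here means a stronger inhibitor, a higher number a weaker inhibitor:
Compound 1 `CC(C)(Oc1ccc(Cl)cc1)C(=O)N1CCN(c2nc(N)nc3sc(-c4ccc(F)cc4)nc23)CC1` gives > 10000 nM, which is a limit of the assay rather than a number.
Compound 2 `Nc1nc(N2CCN(C(=O)COc3ccc(Cl)cc3)CC2)c2nc(CCc3ccc(F)cc3)sc2n1` gives 4400 nM.
Compound 3 `Nc1nc(N2CCN(C(=O)COc3ccc(Cl)cc3)CC2)c2nc(CCOc3ccc(F)cc3)sc2n1` gives 3540 nM.

Compound 1 therefore stands at the limit of > 10000 nM in this assay, at which 1 of the 3 values shown sits, while the other two compounds gave numbers. Compound 4 `COc1ccc(OCC(=O)N2CCN(c3nc(N)nc4sc(-c5ccc(F)cc5)nc34)CC2)cc1` has not been measured. It differs from compound 1 by a group of 10 heavy atoms (8 carbon, 2 oxygen; one six-membered aromatic ring of carbon only) in place of a group of 11 heavy atoms (9 carbon, 1 oxygen, 1 chlorine; one six-membered aromatic ring of carbon only), on a carbonyl carbon. Within the data shown here, the only measured step, a 1.2-fold lower number from compound 2 to compound 3 (0.09 log units; within the scatter), concerns a change at another place and lies within the scatter, so it gives no guide to this change. Compounds 2 and 3 carry a related group on the same carbonyl carbon and gave numbers, yet they differ from compound 4 elsewhere too. Compound 4 is thus estimated at 8000 nM, in a range from 2000 nM to 30000 nM, an expected step of an at least 1.2-fold lower number from compound 1 to compound 4 (0.09 log units; that floor lies within the scatter).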

Compound 4, half-maximal inhibitory concentration: 40 nM
Compound 4: the middle estimate sits 200-fold (2.30 log units) above what was measured, and the stated range ends above it.
By their numbers in this assay, from the lowest: compound 4; then compounds 3 and 2 (each within the scatter of the next). At a limit, above all of these: compound 1.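

In this assay, among these compounds, changing only the group on the carbonyl carbon gives an at least 250-fold lower number from compound 1 to compound 4 (2.39 log units; beyond the scatter) and so shows that this position can move the result strongly, which the earlier compounds, whose one measured step lay elsewhere, could not show. Compound 1, at > 10000 nM, is a limit of the assay and not a number, so the true step may be larger still. The (4-methoxyphenoxy)methyl group differs from the group it replaces in more than one feature, including the loss of chlorine, and the compounds shown do not separate these features. As far as these compounds go, how a (4-ethoxyphenoxy)methyl or (4-fluorophenoxy)methyl group would behave here remains open.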